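The compounds below may be only part of what the source reports. "The series", "measured", "known", "first", "only" and "open" are said of these compounds alone.

Working notes on the series.

Going by the values given here, compound 1 `COc1ccc(C2CC(Nc3nc4ccc(C)cc4s3)=NN2C(C)=O)cc1O` is the only member of the set with a full result: in a functional assay on the whole organism (strain albino) with Mus musculus as the target, with a stated time of 0.5 h (a lower number here means that less compound is needed, a higher number that more compound is needed for the effect), compound 1 gives 75.6 umol/kg. Compound 2 `CC(=O)N1N=C(Nc2nc3ccc([N+](=O)[O-])cc3s2)CC1c1ccc(O)cc1` carries no number in this assay; for compound 2 the entry reads "not determined" (no result reported). Compound 3 `CC(=O)N1N=C(Nc2nc3ccc(C)cc3s2)CC1OC1=CC=C1` stands likewise without a single number in this assay; for compound 3 the entry reads "not determined" (no result reported), and one further entry in the set is also without a number, so compound 3 has no position on the numbers shown and no step from it can be counted.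

Compound 4 `CC(=O)N1N=C(Nc2nc3ccc(C)cc3s2)CC1c1ccc(O)cc1` is the next member to be measured in this assay. It differs from compound 3 in one place: a group of 7 heavy atoms (6 carbon, 1 oxygen; one six-membered aromatic ring of carbon only) in place of a group of 5 heavy atoms (4 carbon, 1 oxygen; one four-membered non-aromatic ring of carbon only), on a saturated ring carbon

Among the compounds with values here, since no measured step exists between compound 3 and compound 4, and compound 3 itself has no number, no direction and no size for this change can be taken from the set. The closest reference with a number is compound 1, which shares the acetyl-bearing core and the methyl-substituted fused ring of compound 4, and differs from it only on the aromatic ring attached to the saturated ring carbon; that pair is not a counted step here, so it serves only as an anchor.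

Compound 4 is expected to fall near 80 umol/kg, in the range 30 umol/kg to 220 umol/kg, with a wide margin given that the estimate rests on compound 1 alone.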

Compound 4, dose for half-maximal effect: 54.3 umol/kg
Compound 4: middle estimate off by 1.5-fold (0.17 log units), on the high side; measured number inside the range.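

In this assay the series now has its first readable step at this position: 4-hydroxyphenyl in place of 3-hydroxy-4-methoxyphenyl on the saturated ring carbon gives a 1.4-fold lower number from compound 1 to compound 4 (0.14 log units; within the scatter). Going by these compounds alone, for this pair, the two aryl groups cannot be told apart, so the read-out at this position does not depend on the difference between them, although two compounds show only this one change and support no wider pattern. Nothing at hand explains why the two groups give numbers this close, and no measurement of any property of either group bears on the result.

On these data alone, the step from compound 3 to compound 4 cannot be read, as compound 3 has no number, and compound 2, which differs from compound 4 on the fused ring system's substituent, has none either, so that substituent remains untested here. Also open, as far as these compounds go, is what happens on the saturated ring carbon when the aryl group gives way to a group of another kind, such as a basic amine, a carboxylic acid or a longer alkyl chain.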